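The source may report more compounds than this note shows. Statements on the series, on what has been measured and on what is new or still open speak of the compounds shown alone.

Measured compounds:
compound 1 `O=S(=O)(NCCCNCc1ccc(Cl)cc1)c1cc(C(F)(F)F)cc(C(F)(F)F)c1`, 2700 nM
compound 2 `O=S(=O)(NCCCNCc1cccc(Cl)c1)c1cc(C(F)(F)F)cc(C(F)(F)F)c1`, 8000 nM

Both compounds share the same core and were tested in a functional assay on Capan-2 cells (Homo sapiens) for inhibition, read by MTT assay, with a stated time of 72 h; on this read-out higher numbers stand for weaker inhibition of growth and lower numbers for stronger inhibition of growth. Compound 1 stands lowest of the two numbers shown; its nearest neighbour is compound 2, and the step of a 3.0-fold higher number from compound 1 to compound 2 (0.47 log units; beyond the scatter) lies beyond the scatter. Compound 3 `COc1ccccc1CNCCCNS(=O)(=O)c1cc(C(F)(F)F)cc(C(F)(F)F)c1` is not yet measured. It differs from compound 1 by 2-methoxyphenyl in place of 4-chlorophenyl on a saturated chain carbon bound to an amine nitrogen. Going by the values given here, the only measured step that bears on this change is a 3.0-fold higher number from compound 1 to compound 2 (0.47 log units; beyond the scatter), which shows that moving the chlorine on the same ring already costs a modest amount of potency. Among the compounds with values here, a methoxy group in a new position on that ring is a larger change than a chlorine shift, so a modest loss beyond the scatter is expected, though the single comparison gives little guidance on its size. The expected step is a 2.0-fold higher number from compound 1 to compound 3 (0.31 log units; beyond the scatter). Compound 3 is therefore estimated at 5500 nM, with a range from 1500 nM to 20000 nM.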

Compound 3, concentration for 50% growth inhibition: 6000 nM
Compound 3: the middle estimate sits 1.1-fold (0.04 log units) below what was measured, and the stated range covers the measured number.
By their numbers in this assay, from the lowest: compound 1; then compounds 3 and 2 (each within the scatter of the next).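

In this assay, 2-methoxyphenyl in place of 4-chlorophenyl also gives a weaker result (a 2.2-fold higher number from compound 1 to compound 3 (0.35 log units; beyond the scatter)), so a ring carrying no chlorine at all falls short of compound 1, just as the 3-chlorophenyl did. Compound 3 cannot be told apart from compound 2 (a 1.3-fold lower number from compound 2 to compound 3 (0.12 log units; within the scatter)), so on this saturated chain carbon bound to an amine nitrogen, these two different ring groups come out alike. Nothing at hand accounts for either step.

The compounds shown leave open whether the edge of compound 1 belongs to the chlorine or to its place on the ring, a question that a 2-chlorophenyl or a 4-methoxyphenyl group would address. They also leave open how an unsubstituted phenyl or a longer chain would fare.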